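The source may report more compounds than this note shows. Statements on the series, on what has been measured and on what is new or still open speak of the compounds shown alone.

In a functional assay on MT2 cells (Homo sapiens) for cytotoxicity, read by MTT assay (a lower number here means that less compound is tolerated, a higher number that more compound is tolerated), compound 1 (`Clc1ccc(Nc2nccs2)cc1OCc1ccsc1`) gives 38000 nM and compound 2 (`Clc1ccc(Nc2nccs2)cc1OCc1nccs1`) gives 20000 nM so that compound 2 stands level with compound 1 within the scatter. Compound 3 (`Clc1ccc(Nc2nccs2)cc1OCC1CCCCC1`) carries cyclohexyl in place of 1,3-thiazol-2-yl on a saturated chain carbon bound to an oxygen on an aromatic ring, and cyclohexyl in place of 1,3-thiazol-2-yl on a saturated chain carbon bound to an oxygen on an aromatic ring gives the full count of that change. For the measured compounds named here, the only measured step is a 1.9-fold lower number from compound 1 to compound 2 (0.28 log units; within the scatter) on exchanging thiophen-3-yl for 1,3-thiazol-2-yl at the same place. Going by the values given here, it bears only loosely on the new change, since no measured compound carries a non-aromatic ring of carbon only at this place. With that single step as the guide, no step beyond the scatter is expected in this assay and no firm direction can be drawn, although a larger step cannot be excluded. The estimated change is a 1.3-fold higher number from compound 2 to compound 3 (0.10 log units; within the scatter) and remains a tentative expectation. Compound 3 is estimated at 25000 nM with an expected range from 10000 nM to 60000 nM as the likely span.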

Compound 3, half-maximal cytotoxic concentration: 15000 nM
Estimate against measurement, compound 3: 1.7-fold (0.22 log units) above, and the stated range covers the measured number.
By their numbers in this assay, from the lowest: compounds 3, 2 and 1 (each within the scatter of the next, the first and the last beyond it).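

In this assay, the group on the saturated chain carbon bound to an oxygen on an aromatic ring need be neither aromatic nor hetero-atom-bearing for the number to stay within the scatter: cyclohexyl, a six-membered non-aromatic ring of carbon only with 0 hydrogen-bond acceptors, in place of 1,3-thiazol-2-yl gives a 1.3-fold lower number from compound 2 to compound 3 (0.12 log units; within the scatter). Set against thiophen-3-yl, the same cyclohexyl gives a 2.5-fold lower number from compound 1 to compound 3 (0.40 log units; beyond the scatter), the first step at this place to pass the scatter, though it stays modest and compound 2 remains within the scatter of both neighbours, so the three ring types do not fall into clearly separate levels. Nothing on hand gives a reason for either step.

Open, on these data alone, is whether an amine or a carboxylic acid on this ring, or a longer chain in its place, would move the number further than these steps do. Also open, as far as these compounds go, is whether the separation between compound 1 and compound 3 would persist with a different group elsewhere on the shared core, which all three compounds carry unchanged.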